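Fluoro in Place of Hydrogen: Compound 3 to Compound 4

The source may hold more compounds than are shown below. What is called first, only, known or untested is meant among the compounds shown, and "the series" means these compounds.

Of the compounds shown here, three sharing one core have been tested in a functional assay on HeLa cells (Homo sapiens) for cytotoxicity, read by MTT assay, with a stated time of 2 days, tested at 0.1 uM; on this read-out higher numbers stand for a weaker effect at the one concentration tested and lower numbers for a stronger effect. Compound 1 `CC(=O)c1cc(-c2ccccc2)cc2cc(-c3ccccc3)[nH]c12` gives 72.3% in this assay. Compound 2 `COc1ccc(-c2cc(C(C)=O)c3[nH]c(-c4ccccc4)cc3c2)cc1`, which carries methoxy in place of hydrogen on an aromatic carbon, gives 87.9%, a change of a number 15.6 percentage points higher from compound 1 to compound 2 (beyond the scatter). Compound 3 `CC(=O)c1cc(/C=C/c2ccccc2)cc2cc(-c3ccccc3)[nH]c12`, which carries 2-phenylethenyl in place of phenyl on an aromatic carbon, gives 99.1%; the change is a number 26.8 percentage points higher from compound 1 to compound 3 (beyond the scatter), and set against compound 2 it is a number 11.2 percentage points higher from compound 2 to compound 3 (beyond the scatter). Compound 3 therefore stands highest of the three numbers in this assay, nearest to compound 2 and furthest from compound 1, both gaps beyond the scatter.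

Compound 4 `CC(=O)c1cc(/C=C/c2ccc(F)cc2)cc2cc(-c3ccccc3)[nH]c12` differs from compound 3 by fluoro in place of hydrogen on an aromatic carbon. Going by the values given here, no measured step exchanges hydrogen for fluoro, so nothing bears on this change directly; the only comparable single-substituent step, from compound 1 to compound 2, was modest in size, and compound 3 already sits near the top of what this read-out can report. The step from compound 3 to compound 4 is therefore expected to be a number 2.1 percentage points lower from compound 3 to compound 4 (within the scatter), within the scatter. Compound 4 is estimated at 97%, between 86% and 100%.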

Compound 4, a percentage reported as activity, at one concentration (the size of the read-out at that concentration, not a potency): 74.2%
Compound 4: the middle estimate sits 22.8 percentage points above what was measured; measured number outside the range, below it.
By their numbers in this assay, from the lowest: compounds 1 and 4 (each within the scatter of the next); then compound 2; then compound 3.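

In this assay, the 2-phenylethenyl group proves sensitive to a change of a single atom: fluoro in place of hydrogen, para to a large group, gives a number 24.9 percentage points lower from compound 3 to compound 4 (beyond the scatter), a step that the earlier compounds, which held no such exchange, could not have shown. The result also alters how the groups at this place compare, since 2-(4-fluorophenyl)ethenyl in place of 4-methoxyphenyl gives a number 13.7 percentage points lower from compound 2 to compound 4 (beyond the scatter), the opposite direction to the step from 4-methoxyphenyl to 2-phenylethenyl, while 2-(4-fluorophenyl)ethenyl in place of phenyl gives a number 1.9 percentage points higher from compound 1 to compound 4 (within the scatter), so the weak reading seen with 2-phenylethenyl does not hold for the extended group as such. No supporting data are available to account for this shift in the read-out.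

The compounds shown leave open whether the step is particular to fluoro or would also appear with chloro, a methoxy group or an amine at the same place on the ring. They also leave open whether fluoro on the phenyl group of compound 1 would give a step of similar size, and how the read-out would behave at other concentrations.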